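Halogen swap on the benzylamine ring of a sulfonamide series

A few compounds are considered here, and "the series" means these few. Any claim that something is new, unique, unknown or untested is made for them only; others in the source may bear on it.

Three compounds share one sulfonamide core and differ only on the benzyl ring. Compound 1 `CC(C)(C)c1ccc(CNCCCNS(=O)(=O)c2cc(C(F)(F)F)cc(C(F)(F)F)c2)cc1` gives 2900 nM in a functional assay on A2780 cells (Homo sapiens) for inhibition, read by MTT assay, with a stated time of 72 h (on this read-out higher numbers stand for weaker inhibition of growth and lower numbers for stronger inhibition of growth), compound 2 `O=S(=O)(NCCCNCc1ccccc1)c1cc(C(F)(F)F)cc(C(F)(F)F)c1` gives 4900 nM, and compound 3 `O=S(=O)(NCCCNCc1ccc(Br)cc1)c1cc(C(F)(F)F)cc(C(F)(F)F)c1` gives 2600 nM. Compound 3 stands nearest to compound 1, with a 1.1-fold lower number from compound 1 to compound 3 (0.05 log units; within the scatter), and furthest from compound 2, with a 1.9-fold lower number from compound 2 to compound 3 (0.28 log units; within the scatter); neither gap is beyond the scatter, so the three sit together.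

Compound 4 `O=S(=O)(NCCCNCc1ccc(Cl)c(Cl)c1)c1cc(C(F)(F)F)cc(C(F)(F)F)c1` differs from compound 3 in one place: 3,4-dichlorophenyl in place of 4-bromophenyl on a saturated chain carbon bound to an amine nitrogen. For the measured compounds named here, the steps that bear on it are those that changed the same ring, a 1.9-fold lower number from compound 2 to compound 3 (0.28 log units; within the scatter) and a 1.1-fold lower number from compound 1 to compound 3 (0.05 log units; within the scatter), and both stayed within the scatter, as did a 1.7-fold higher number from compound 1 to compound 2 (0.23 log units; within the scatter). Every change seen on this ring has therefore left the number where it was, and a second chlorine is expected to do the same, giving a 1.1-fold lower number from compound 3 to compound 4 (0.05 log units; within the scatter) as a step that is not expected to exceed the scatter. Compound 4 is accordingly estimated at 2300 nM, with a range from 1000 nM to 5500 nM.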

Compound 4, concentration for 50% growth inhibition: 1500 nM
Beside the measured number, compound 4's estimate is 1.5-fold (0.19 log units) above it; the range from low to high includes it.
By their numbers in this assay, from the lowest: compounds 4, 3, 1 and 2 (each within the scatter of the next, the first and the last beyond it).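

In this assay, for the compounds shown here, the step of a 3.3-fold lower number from compound 2 to compound 4 (0.51 log units; beyond the scatter) is the only one on this ring that lies beyond the scatter, so 3,4-dichlorophenyl in place of phenyl shows that this position can move the number, if modestly, whereas 4-bromophenyl and 4-(tert-butyl)phenyl did not separate from phenyl. The separation is limited to that one pair, since the step of a 1.7-fold lower number from compound 3 to compound 4 (0.24 log units; within the scatter) and the step of a 1.9-fold lower number from compound 1 to compound 4 (0.29 log units; within the scatter) both stay within the scatter, leaving compound 4 not distinguishable from compound 3 or compound 1. Nothing available explains the difference between compound 2 and compound 4.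

From the compounds shown here alone, whether a single chlorine would be enough to separate from compound 2 stays open, as does whether a methoxy group or a nitrile on this ring would do the same. Going by these compounds, it is also open whether the step would hold with a longer chain in the linker.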